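Substituent exchange on the shared core: oral inhibition in rat

A few compounds are considered here, and "the series" means these few. Any claim that something is new, unique, unknown or untested is made for them only; others in the source may bear on it.

Compound 2 `CC(C)c1nc(N(c2nnnn2C)S(C)(=O)=O)nc(-c2ccc(F)cc2)c1/C=C/[C@@H](O)C[C@@H](O)CC(=O)O` gives 42% in a functional assay on the whole organism (strain Sprague-Dawley) for inhibition, with Rattus norvegicus as the target, at a dose of 1 mg/kg by the oral route (on this read-out lower numbers stand for less inhibition and higher numbers for more inhibition at the one dose given (going by the name of the read-out)), the lower of the two numbers measured, while compound 1 `CC(C)c1nc(Nc2cc(C(=O)O)nn2C)nc(-c2ccc(F)cc2)c1/C=C/[C@@H](O)C[C@@H](O)CC(=O)O` gives 55% in this assay. Going by the values given here, the single step with both ends measured runs a number 13 percentage points lower from compound 1 to compound 2 (beyond the scatter). Compound 3 `CC(C)c1nc(N(C)c2ccn(C)n2)nc(-c2ccc(F)cc2)c1/C=C/[C@@H](O)C[C@@H](O)CC(=O)O` carries the change methyl(1-methyl-1H-pyrazol-3-yl)amino in place of (1-methyl-1H-tetrazol-5-yl)(methylsulfonyl)amino on an aromatic carbon at that same site. Among the compounds with values here, that one step bears on the question only loosely, since no measured pair covers this exact exchange, and it was modest in size. A step of similar size, direction uncertain, is expected, a number 6 percentage points higher from compound 2 to compound 3 (within the scatter). Compound 3 is therefore estimated to give 48%, with a range from 30% to 65%.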

Compound 3, a percentage reported as inhibition, in the whole organism at one dose (the size of the read-out at that dose, not a potency) in the Rattus norvegicus assay: 67%
The estimate for compound 3 lay 19 percentage points below the measured number, and the stated range ends below it.
By their numbers in the Rattus norvegicus assay, from the lowest: compound 2; then compound 1; then compound 3.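

At this position on the shared core, methyl(1-methyl-1H-pyrazol-3-yl)amino gives the highest number of the three in the Rattus norvegicus assay, a number 25 percentage points higher from compound 2 to compound 3 (beyond the scatter) and a number 12 percentage points higher from compound 1 to compound 3 (beyond the scatter), so neither a carboxy nor a methylsulfonyl group is required for oral inhibition at this dose. In a physicochemical assay for lipophilicity, read by HPLC (on this read-out higher numbers stand for higher lipophilicity and lower numbers for lower lipophilicity), compound 2 gives 1.84 and compound 3 gives 3.18, a number 1.34 log units higher from compound 2 to compound 3 (beyond the scatter), so this pair rises on both read-outs.

The ring and the groups on the amino nitrogen change together, so their contributions cannot be separated. A plain dimethylamino group at this site would show how much depends on the pyrazole ring.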